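Aryl halogen swap on the enone of compound 2

The compounds below may be only part of what the source reports. "The series", "measured", "known", "first", "only" and "open" are said of these compounds alone.

Measured so far:
compound 1, `COc1ccc(-c2cc(/C=C/C(=O)c3ccc(N)cc3)[nH]n2)cc1`: 88%
compound 2, `COc1cc(-c2cc(/C=C/C(=O)c3ccc(Cl)c(Cl)c3)[nH]n2)cc(OC)c1OC`: 91%

Both numbers come from a functional assay on 786-0 cells (Homo sapiens) for cytotoxicity, read by sulforhodamine B assay, with a stated time of 48 h, tested at 1 uM; on this read-out higher numbers stand for a weaker effect at the one concentration tested and lower numbers for a stronger effect. In this assay compound 1 gives 88% and compound 2 gives 91%; the two values lie within the usual scatter of each other, so neither compound can be set apart from the other on these numbers. Both read as a weak effect at the one concentration tested. Going by the values given here, no step between measured compounds has been worked out for this pair, so nothing more than this closeness can be said of it.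

The next compound, compound 3, `COc1cc(-c2cc(/C=C/C(=O)c3ccc(F)c(F)c3)[nH]n2)cc(OC)c1OC`, keeps the core of compound 2 and changes one group: 3,4-difluorophenyl in place of 3,4-dichlorophenyl on a carbonyl carbon. Among the compounds with values here, with only two measured compounds, both at high read-outs and no computed step to lean on, no movement beyond the scatter is expected in this assay from this change, in either direction. Compound 3 is therefore expected to give 91%, with a range from 80% to 100%. The step this estimate means, no change at the digits printed from compound 2 to compound 3 (within the scatter), is expected to stay inside the scatter.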

Compound 3, a percentage reported as activity, at one concentration (the size of the read-out at that concentration, not a potency): 93%
For compound 3 the middle estimate is 2 percentage points below the measured one; low and high end bracket the measured number.
By their numbers in this assay, from the lowest: compounds 1, 2 and 3 (each within the scatter of the next).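

In this assay, going by these compounds alone, the exchange of 3,4-dichlorophenyl for 3,4-difluorophenyl on a carbonyl carbon gives a number 2 percentage points higher from compound 2 to compound 3 (within the scatter) and so provides the first comparison that turns on one place alone. At this position the read-out at the one concentration tested does not separate the two halogens, so chlorine and fluorine count as interchangeable here for this read-out only, and the high numbers of both compounds leave the pair on the weak side of the assay. No measurement at hand bears on this result or accounts for it.

Within the data shown here, whether a nitrile or a carboxylic acid on that phenyl, in place of the two halogens, would move the read-out beyond the scatter remains open, since both groups at this position so far are halogens on the same ring. Also open, as far as these compounds go, is whether compound 2 and compound 3 would stay together at a different concentration, as a single-concentration percentage gives the size of the effect at that concentration and not a potency.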